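Aryl sulfone variation on the shared core: compound 4

A few compounds are considered here, and "the series" means these few. Any claim that something is new, unique, unknown or untested is made for them only; others in the source may bear on it.

Measured so far:
compound 1 `Cc1ccc2ncc(S(=O)(=O)c3ccc(Cl)c(Cl)c3)c(N3CCC(C)CC3)c2c1` — in an assay on isolated protein for displacement of a labelled ligand from metabotropic glutamate receptor 5 (Homo sapiens), with a stated time of 60 min, tested at 1 uM (on this read-out higher numbers stand for more inhibition at the one concentration tested (going by the name of the read-out) and lower numbers for less inhibition), compound 1 gives 82%
compound 2 `Cc1ccc2ncc(S(=O)(=O)c3ccc(C)c(C)c3)c(N3CCC(C)CC3)c2c1` — in this assay compound 2 gives 90%
compound 3 `Cc1ccc2ncc(S(=O)(=O)c3cccc(F)c3)c(N3CCC(C)CC3)c2c1` — in this assay compound 3 gives 94%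

Compound 3 holds the highest of the three numbers. Its gap to compound 1 is beyond the scatter, a number 12 percentage points higher from compound 1 to compound 3 (beyond the scatter), while its gap to compound 2 is not, a number 4 percentage points higher from compound 2 to compound 3 (within the scatter), so compound 2 and compound 3 cannot be ordered on these data.

Compound 4 `COc1cccc(S(=O)(=O)c2cnc3ccc(C)cc3c2N2CCC(C)CC2)c1` differs from compound 3 in one place: methoxy in place of fluoro on an aromatic carbon. All three measured steps also change only the aryl group on the sulfonyl sulfur, and they were small: a number 8 percentage points higher from compound 1 to compound 2 (within the scatter) and a number 4 percentage points higher from compound 2 to compound 3 (within the scatter) within the scatter, a number 12 percentage points higher from compound 1 to compound 3 (beyond the scatter) modest. Among the measured compounds shown here, none of them exchanges fluoro for methoxy, so the new change has no direct precedent; what the measured steps show is that across these several substitution patterns on this aryl group the number in this assay stays high.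

The step from compound 3 to compound 4 is therefore expected to stay within the scatter, a number 4 percentage points lower from compound 3 to compound 4 (within the scatter), with a slight downward lean only since compound 3 sits at the top of the present range. Compound 4 is estimated at 90%, within 78% to 98%.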

Compound 4, a percentage reported as inhibition, at one concentration (the size of the read-out at that concentration, not a potency): 96%
Compound 4: the middle estimate sits 6 percentage points below what was measured; measured number inside the range.
By their numbers in this assay, from the lowest: compounds 1, 2, 3 and 4 (each within the scatter of the next, the first and the last beyond it).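

In this assay, methoxy in place of fluoro on this aromatic carbon, meta to a large group, gives a number 2 percentage points higher from compound 3 to compound 4 (within the scatter), so this position takes a methoxy group, which counts a hydrogen-bond acceptor where fluoro counts none, with no shift that can be read. Replacing the other aryl groups on the sulfonyl sulfur with 3-methoxyphenyl gives a number 6 percentage points higher from compound 2 to compound 4 (within the scatter) for 3,4-dimethylphenyl and a number 14 percentage points higher from compound 1 to compound 4 (beyond the scatter) for 3,4-dichlorophenyl, so 3-methoxyphenyl, like 3-fluorophenyl, separates from the dichloro compound but not from the dimethyl compound, which is the exception to any split between these singly substituted aryl groups and the doubly substituted ones. No measurement is available that bears on what lies behind these numbers.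

On these data alone, whether this aromatic carbon also holds the number with a hydroxyl, an amine, a carboxylic acid or a longer chain such as butoxy remains open. Also open, as far as these compounds go, is whether 3-fluorophenyl and 3-methoxyphenyl would separate in a full concentration-response measurement, since a read-out at a single concentration gives no potency.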